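The source may hold more compounds than are shown below. What is called first, only, known or untested is meant among the compounds shown, and "the series" means these compounds.

Measured so far in a functional assay on HepG2 cells (Homo sapiens) for antiproliferative activity, read by MTT assay, with a stated time of 48 h; on this read-out higher numbers stand for weaker inhibition and lower numbers for stronger inhibition:
compound 1 `O=C(Nc1cccc(CNc2nccnc2Cl)c1)Nc1cccc2ccccc12` — compound 1 gives > 40000 nM
compound 2 `O=C(Nc1cccc(CNc2nccnc2Cl)c1)Nc1ccccc1F` — compound 2 gives 10500 nM
compound 3 `CC(C)(C)c1ccc(NC(=O)Nc2cccc(CNc3nccnc3Cl)c2)cc1` — compound 3 gives 7550 nM

The value of compound 1 is a limit of this assay and not a number (the limit of > 40000 nM in this assay, at which 1 of the 3 values shown sits). Compound 2 and compound 3 sit within the usual scatter of each other, so no order between them is claimed. Compound 4 `O=C(Nc1cccc(CNc2nccnc2Cl)c1)Nc1ccc(Cl)cc1Cl` has not yet been measured. It differs from compound 2 in one place: 2,4-dichlorophenyl in place of 2-fluorophenyl on an amide-type nitrogen. For the measured compounds named here, no measured pair shows this change, so the step is judged from the three numbers alone. The step of a 1.5-fold lower number from compound 2 to compound 4 (0.18 log units; within the scatter) is expected to be small, within or only just beyond the scatter, leaning toward a lower number. Compound 4 is expected to give about 7000 nM, in the range 2500 nM to 20000 nM.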

Compound 4, half-maximal inhibitory concentration: 7230 nM
Estimate against measurement, compound 4: 1.0-fold (0.01 log units) below; low and high end bracket the measured number.
By their numbers in this assay, from the lowest: compounds 4, 3 and 2 (each within the scatter of the next). At a limit, above all of these: compound 1.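

In this assay, replacing 2-fluorophenyl with 2,4-dichlorophenyl on the amide-type nitrogen gives a 1.5-fold lower number from compound 2 to compound 4 (0.16 log units; within the scatter). For the compounds shown here, this is the first measured step at this position, and it shows that this exchange of substituted phenyl groups, from one fluorine to two chlorines, stays within the scatter. Nothing at hand bears on a cause for this step.

Still open, from the compounds shown here alone, is whether a carboxylic acid or an amine on the phenyl group would give a step beyond the scatter. A longer chain between this nitrogen and the phenyl group also remains untested in the compounds shown.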